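The source may report more compounds than this note shows. Statements on the series, on what has been measured and on what is new or still open speak of the compounds shown alone.

Compound 1 `O=C(c1ccccc1)c1cc(Cl)ccc1OCCn1ccc(=O)[nH]c1=O` in an ADME assay on MT4 cells (Homo sapiens) for cytotoxicity, read by MTT assay, with a stated time of 4 days (a lower number here means that less compound is tolerated, a higher number that more compound is tolerated), gives > 337000 nM, a limit of the assay rather than a number.
Compound 2 `Cc1cc(C)cc(C(=O)c2cc(Cl)ccc2OCCn2c(C)cc(=O)[nH]c2=O)c1` in this assay gives > 303000 nM, again a limit and not a number.
Compound 3 `Cc1cccc(C(=O)c2cc(Cl)ccc2OCCn2ccc(=O)[nH]c2=O)c1` in this assay gives > 325000 nM, also a limit.

Compound 2 therefore stands where the other two stand: at a limit, with no numbered value among the three, as shown by the limit of > 303000 nM in this assay, at which 1 of the 3 values shown sits, the limit of > 325000 nM in this assay, at which 1 of the 3 values shown sits, and (the limit of > 337000 nM in this assay, at which 1 of the 3 values shown sits). For the measured compounds named here, the one measured step that differs in a single place, a step that the two limits leave unreadable from compound 1 to compound 3, is a methyl in place of hydrogen on an aromatic carbon, and the two limits leave its size unreadable.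

Compound 4 `Cc1cc(C)cc(C(=O)c2cc(Cl)ccc2OCCn2cc(C)c(=O)[nH]c2=O)c1` is not yet measured. It differs from compound 2 by a group of 9 heavy atoms (5 carbon, 2 nitrogen, 2 oxygen; one six-membered aromatic ring with 2 hetero atoms) in place of a group of 9 heavy atoms (5 carbon, 2 nitrogen, 2 oxygen; one six-membered aromatic ring with 2 hetero atoms), on a saturated chain carbon, two bonds along the chain from an oxygen on an aromatic ring: the two have the same atoms joined differently, and the exchange sits on a saturated chain carbon, two bonds along the chain from an oxygen on an aromatic ring.

Going by the values given here, no measured step in this assay can be read, so nothing in these three values points toward a step beyond the scatter in either direction. Compound 4 is therefore expected to sit at the limit again, at about 300000 nM. The expected range for compound 4 runs from 100000 nM to 900000 nM. This expectation amounts to a step of a number no higher from compound 2 to compound 4 (the limit leaves the size open).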

Compound 4, half-maximal cytotoxic concentration: > 303000 nM
Compound 4: only a limit was reported (the forecaster's own chance of this, stated with the estimate: 85%); middle value at least 1.0-fold (0.00 log units) away from the limit.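

Compound 2 and compound 4 both give only a limit in this assay, so the step between them, the same atoms joined differently, cannot be read. The compounds shown leave open at what concentration any of the four harms the cells, and whether any change in structure shifts that concentration.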